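The compounds below may be only part of what the source reports. "The series", "measured", "known", "first", "only" and "open" are said of these compounds alone.

Series notes. Compound 1 `Cc1nc(Nc2ccc(Cl)c(Cl)c2)sc1C(=O)/C=C/c1ccccc1` is the parent; in a functional assay on NCI-H460 cells (Homo sapiens) for cytotoxicity, read by MTT assay (on this read-out higher numbers stand for weaker inhibition and lower numbers for stronger inhibition), compound 1 gives 22700 nM. Compound 2 `Cc1nc(Nc2ccc(Cl)c(Cl)c2)sc1C(=O)/C=C/c1ccc(Cl)cc1` carries chloro in place of hydrogen on an aromatic carbon. In this assay compound 2 is reported only as a limit of the assay, > 25000 nM. The change an at least 1.1-fold higher number from compound 1 to compound 2 (0.04 log units; that floor lies within the scatter) is therefore known only as a floor, and its size rests on (the limit of > 25000 nM in this assay, at which 1 of the 2 values shown sits). Compound 3 `COc1ccc(/C=C/C(=O)c2sc(Nc3ccc(Cl)c(Cl)c3)nc2C)cc1` has not been tested in this assay. It differs from compound 2 in that (methoxy in place of chloro on an aromatic carbon). For the measured compounds named here, the only measured step, from compound 1 to compound 2, was a swap at the same aromatic carbon and reached no more than the assay limit, so no step beyond the scatter is expected in this assay from this second swap. The implied step that the limit leaves unreadable from compound 2 to compound 3 is expected to stay within the scatter. Compound 3 is estimated at 27000 nM, between 13000 nM and 55000 nM, with a limit value again quite likely.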

Compound 3, half-maximal inhibitory concentration: > 25000 nM
Compound 3: only a limit was reported (the forecaster's own chance of this, stated with the estimate: 60%); the middle value lies beyond the limit too.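

In this assay compound 3 is also reported only as a limit of the assay, > 25000 nM. Methoxy on this aromatic carbon thus joins chloro in giving no numeric value, and against the unsubstituted parent the result is an at least 1.1-fold higher number from compound 1 to compound 3 (0.04 log units; that floor lies within the scatter). The step between the 4-chlorophenyl and 4-methoxyphenyl compounds cannot be read, and any real size of the changes at this position stays hidden because the values collect at the limit: the limit of > 25000 nM in this assay, at which 2 of the 3 values shown sit.

On these data alone, whether compound 2 and compound 3 differ at all remains open. Also open, as far as these compounds go, is whether an amine or a carboxylic acid on this aromatic carbon would give a readable value lower than that of compound 1, which stands at 22700 nM in this assay.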